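The source may hold more compounds than are shown below. What is called first, only, known or untested is meant among the compounds shown, and "the series" means these compounds.

Measured so far in a functional assay on A549 cells (Homo sapiens) for cytotoxicity, read by MTT assay, with a stated time of 72 h; on this read-out lower numbers stand for stronger inhibition and higher numbers for weaker inhibition:
compound 1 `Fc1ccc(Nc2cc(Nc3ccc(Oc4ccncc4-c4cccnc4)c(F)c3)ncn2)cc1F`, 7630 nM
compound 2 `Fc1cc(Nc2cc(Nc3ccc(Cl)cc3)ncn2)ccc1Oc1ccncc1-c1cccnc1`, 1610 nM
compound 3 `Fc1cc(Nc2cc(Nc3cccc(Cl)c3)ncn2)ccc1Oc1ccncc1-c1cccnc1`, 180 nM

Compound 3 gives the lowest number of the three in this assay; its nearest neighbour is compound 2, with an 8.9-fold lower number from compound 2 to compound 3 (0.95 log units; beyond the scatter), and its furthest is compound 1, with a 42-fold lower number from compound 1 to compound 3 (1.63 log units; beyond the scatter), both steps beyond the scatter.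

Compound 4 `Fc1ccc(Nc2cc(Nc3ccc(Oc4ccncc4-c4cccnc4)c(F)c3)ncn2)cc1` differs from compound 3 by 4-fluorophenyl in place of 3-chlorophenyl on a nitrogen on an aromatic ring. Within the data shown here, two measured steps bear on this. The step of an 8.9-fold lower number from compound 2 to compound 3 (0.95 log units; beyond the scatter) shows that the 4-chlorophenyl gives a modestly higher number than the 3-chlorophenyl, and the step of a 4.7-fold lower number from compound 1 to compound 2 (0.68 log units; beyond the scatter) shows that the 3,4-difluorophenyl, which also carries fluorine at the 4-position of the ring, gives a modestly higher number than the 4-chlorophenyl. Among the measured compounds shown here, no measured pair sets fluorine against chlorine at the same place, so the 4-fluorophenyl is placed by analogy to these two steps only. The expected step for compound 4 is therefore a 14-fold higher number from compound 3 to compound 4 (1.14 log units; beyond the scatter), a modest rise. Compound 4 is expected to give 2500 nM in this assay. The expected range for compound 4 runs from 700 nM to 9000 nM.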

Compound 4, half-maximal inhibitory concentration: 710 nM
Compound 4: the middle estimate sits 3.5-fold (0.55 log units) above what was measured, within the range that was stated.
By their numbers in this assay, from the lowest: compound 3; then compound 4; then compound 2; then compound 1.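

In this assay, among these compounds, the 4-fluorophenyl gives the first comparison of two halogens at one place, and a 2.3-fold lower number from compound 2 to compound 4 (0.36 log units; beyond the scatter) shows that fluoro in place of chloro on this ring shifts the number modestly but beyond the scatter. Hydrogen in place of fluoro on the 3,4-difluorophenyl has a large effect, with an 11-fold lower number from compound 1 to compound 4 (1.03 log units; beyond the scatter), so the extra fluoro is clearly unfavourable in this series. Even so, the 4-fluorophenyl does not match the 3-chlorophenyl, as a 3.9-fold higher number from compound 3 to compound 4 (0.60 log units; beyond the scatter) shows, and compound 3 keeps the lowest number of the four.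

No measurement on hand accounts for any of these steps. Still open, as far as these compounds go, is whether the low number of compound 3 depends on chlorine itself: a 3-fluorophenyl would separate the halogen from its place on the ring, and a 3-methoxyphenyl or 3-aminophenyl would show whether a halogen is needed at all.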